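The source may report more compounds than this note shows. Statements on the series, on what has been measured and on what is new or still open speak of the compounds shown alone.

Three quinazoline hydrazinecarbothioamides were measured in a functional assay on MGC-803 cells (Homo sapiens) for cytotoxicity, read by MTT assay, with a stated time of 72 h; a higher number here means a weaker inhibitor, a lower number a stronger inhibitor. Compound 1 `COc1cc2ncnc(NNC(=S)NC(=O)c3ccc(Cl)cc3)c2cc1OC` gives 3710 nM. Compound 2 `COc1cc2ncnc(NNC(=S)NC(=O)c3ccc(C)cc3)c2cc1OC` gives 19700 nM. Compound 3 `O=C(NC(=S)NNc1ncnc2ccccc12)c1ccccc1Cl` gives 9140 nM, the second highest of the three numbers; its value is lower than that of compound 2 and higher than that of compound 1.

Between compound 1 and compound 2 the single change is methyl in place of chloro on an aromatic carbon, and it produced a 5.3-fold higher number from compound 1 to compound 2 (0.73 log units; beyond the scatter).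

Compound 4 `Cc1ccccc1C(=O)NC(=S)NNc1ncnc2ccccc12` has not been measured. It differs from compound 3 by methyl in place of chloro on an aromatic carbon. The difference between the core of compound 3 and the core of compound 1 is not broken down here. The change from compound 3 to compound 4 is the same kind of change as that from compound 1 to compound 2, but not the same: in the measured pair the site is para to a large group, whereas in compound 4 it is ortho to a large group.

Taking compound 3 as the starting point, a step in the same direction as the measured one is expected, though tempered for the different placement, so the expected step is a 3.0-fold higher number from compound 3 to compound 4 (0.47 log units; beyond the scatter), resting on compound 1 and compound 2 having shown a 5.3-fold higher number from compound 1 to compound 2 (0.73 log units; beyond the scatter). For compound 4 in this assay the estimated value is 27000 nM. The expected range for compound 4 runs from 9000 nM to 80000 nM.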

Compound 4, half-maximal inhibitory concentration: 4240 nM
Estimate against measurement, compound 4: 6.4-fold (0.80 log units) above; measured number below the stated range.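

In this assay, the exchange of chloro for methyl did not carry over from one core to the other: the change that gave compound 2 a weaker number than compound 1 went the opposite way on the second core, with a 2.2-fold lower number from compound 3 to compound 4 (0.33 log units; beyond the scatter). The two steps run in opposite directions, and the gap between them lies beyond the scatter: the same change on two cores in this assay, a 5.3-fold higher number (0.73 log units; beyond the scatter) from compound 1 to compound 2 and a 2.2-fold lower number (0.33 log units; beyond the scatter) from compound 3 to compound 4, 11-fold (1.06 log units) apart, beyond the scatter of two such steps. This shows that, within these four compounds, the step seen on one pair cannot be transferred to the other, but it does not show which difference is responsible, as the two pairs differ in their core and also in where the change sits, the 2-chlorophenyl to 2-methylphenyl change being ortho to a large group, and a single pair of each kind cannot separate the two.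

Still open, going by these compounds, is whether the 2-chlorophenyl to 2-methylphenyl change on the core of compound 1 would follow the step of the pair on that core or the step of the pair on the other one. Also open, on these data alone, is how an amine, a nitrile or a carboxylic acid would read in this assay at the place held by chloro and methyl.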